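The source may hold more compounds than are shown below. What is called first, only, known or untested is meant among the compounds shown, and "the series" means these compounds.

Compound 2 `O=C(Nc1ccc(S(=O)(=O)Nc2ccccc2)cc1)c1ccc(Cl)cc1F` is measured in a functional assay on HEK293 cells for agonist activity at probable G-protein coupled receptor 27 (Homo sapiens), read by a luciferase reporter and beta-arrestin recruitment, with a stated time of 10 min (a higher number here means that more compound is needed for the effect, a lower number that less compound is needed), where compound 2 gives 3980 nM. Compound 1 `O=C(Nc1ccc(S(=O)(=O)Nc2ccccc2)cc1)c1cc2ccccc2oc1=O` gives 7760 nM in this assay, and the two numbers lie within the usual scatter of repeated measurements, so neither compound can be set above the other. Compound 3 `O=C(Nc1ccc(S(=O)(=O)Nc2ccccc2)cc1)c1cc(F)c(Cl)cc1F` has not yet been measured. It differs from compound 2 by fluoro in place of hydrogen on an aromatic carbon. Going by the values given here, no step between two measured compounds covers this kind of change, so no shift beyond the scatter is expected in either direction in this assay. Compound 3 is therefore estimated to give 3500 nM, most likely between 1200 nM and 10000 nM. For compound 3 this expectation amounts to a step of a 1.1-fold lower number from compound 2 to compound 3 (0.06 log units; within the scatter).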

Compound 3, half-maximal effective concentration: 141 nM
The estimate for compound 3 lay 25-fold (1.39 log units) above the measured number; measured number outside the range, below it.
By their numbers in this assay, from the lowest: compound 3; then compounds 2 and 1 (each within the scatter of the next).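

In this assay, going from 4-chloro-2-fluorophenyl to 4-chloro-2,5-difluorophenyl gives a 28-fold lower number from compound 2 to compound 3 (1.45 log units; beyond the scatter) and so shows that this ring carbon, ortho to the chloro group and para to the fluoro group, responds strongly to one added fluorine atom. Compound 1 and compound 2 had shown no difference beyond the scatter, so this is the first clear separation among these compounds. Nothing available explains why this single atom has so large an effect. Going by these compounds, whether a methyl or methoxy group on the same carbon would act like fluoro remains open. So does whether fluoro on the other free ring carbon would do the same.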